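A few compounds are considered here, and "the series" means these few. Any claim that something is new, unique, unknown or untested is made for them only; others in the source may bear on it.

The compounds measured so far:

Compound 1 `Cc1cn([C@H]2CCCN([C@@H](CC(C)C)c3ccc(C(=O)O)c(Oc4cccc(Cl)c4)c3F)C2)c(=O)[nH]c1=O`: 0.57
Compound 2 `CC[C@H](c1ccc(C(=O)O)c(Oc2cccc(Cl)c2)c1OC)N1CCC[C@H](n2cc(C)c(=O)[nH]c2=O)C1`: -0.13
Compound 3 `CC[C@@H](c1ccc(C(=O)O)c(Oc2cccc(Cl)c2)c1OC)N1CCC[C@H](n2cc(C)c(=O)[nH]c2=O)C1`: -0.02

In a physicochemical assay for lipophilicity, using the shake flask method, in phosphate buffer, measured as octanol-water partition, at pH 7.4 (on this read-out higher numbers stand for higher lipophilicity and lower numbers for lower lipophilicity), compound 1 gives 0.57, the highest of the three numbers; compound 3 is nearest and compound 2 furthest, both beyond the scatter. Within the data shown here, the only measured step between compounds differing in one place is a number 0.11 log units higher from compound 2 to compound 3 (within the scatter), which rests on the fact that compounds 2 and 3 differ only in the configuration as drawn and so says nothing about removing a side chain. Compound 4 `Cc1cn([C@H]2CCCN(Cc3ccc(C(=O)O)c(Oc4cccc(Cl)c4)c3F)C2)c(=O)[nH]c1=O` differs from compound 1 by hydrogen in place of isobutyl on a saturated chain carbon bound to an amine nitrogen in a ring and an aromatic carbon. Among the measured compounds shown here, no measured step covers this change, and compounds 2 and 3 differ from compound 1 in more than one place, so their lower values do not isolate it. Compound 4 is nonetheless expected to give a lower number, about -0.6, in a range from -1.3 to 0.1. The expected step is a number 1.17 log units lower from compound 1 to compound 4 (beyond the scatter).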

Compound 4, distribution coefficient: -0.59
The estimate for compound 4 lay 0.01 log units below the measured number; measured number inside the range.
By their numbers in this assay, from the lowest: compound 4; then compounds 2 and 3 (each within the scatter of the next); then compound 1.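

In this assay, swapping isobutyl for hydrogen on this saturated chain carbon gives a number 1.16 log units lower from compound 1 to compound 4 (beyond the scatter), so the read-out depends on what this position carries. The earlier step, a number 0.11 log units higher from compound 2 to compound 3 (within the scatter), changed only the drawn configuration at a chain carbon and could not show the effect of removing the group itself. Nothing measured here gives a cause for the new step.

Going by these compounds, what a methyl group or an amine would give on this same carbon remains open. So does whether the read-out follows chain length here.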